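Swapping cyclohexyl for tert-butyl on a weak hydroxamic acid

A few compounds are considered here, and "the series" means these few. Any claim that something is new, unique, unknown or untested is made for them only; others in the source may bear on it.

Measured in a functional assay on A2780 cells (Homo sapiens) for cytotoxicity, read by MTT assay, with a stated time of 72 h; a lower number here means a stronger inhibitor, a higher number a weaker inhibitor:
Compound 1 `Cc1cc(C)cc(C(=O)N(CCCCCC(=O)NO)CC(=O)NC2CCCCC2)c1`: 160 nM
Compound 2 `CC(C)(C(=O)NC1CCCCC1)N(CCCCCC(=O)NO)C(=O)c1ccccc1`: 295000 nM
Compound 3 `CN(C)c1ccc(C(=O)N(CCCCCC(=O)NO)C(C)(C)C(=O)NC2CCCCC2)cc1`: 68500 nM

Among these three, compound 2 has the highest number, at 295000 nM. Compound 1 lies far lower at 160 nM, but it differs from compound 2 in more than one place, so the two values show only a wide gap and no effect of any single change. The nearest neighbour of compound 2 is compound 3, and the step there is a 4.3-fold lower number from compound 2 to compound 3 (0.63 log units; beyond the scatter).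

The next compound, compound 4 `CC(C)(C)NC(=O)C(C)(C)N(CCCCCC(=O)NO)C(=O)c1ccccc1`, departs from compound 2 in one place: tert-butyl in place of cyclohexyl on an amide-type nitrogen. Among the compounds with values here, no measured step involves this substituent. Within the data shown here, the only single-change step available, a 4.3-fold lower number from compound 2 to compound 3 (0.63 log units; beyond the scatter), is modest and concerns an aromatic carbon, so it offers a rough guide to size at best and none to direction. On these data alone, on that basis, no step beyond the scatter is expected in this assay, and the direction remains open. The estimated change is a 1.2-fold lower number from compound 2 to compound 4 (0.07 log units; within the scatter). For compound 4 the estimate is 250000 nM, with an expected range from 90000 nM to 600000 nM.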

Compound 4, half-maximal inhibitory concentration: 207000 nM
The estimate for compound 4 lay 1.2-fold (0.08 log units) above the measured number; low and high end bracket the measured number.
By their numbers in this assay, from the lowest: compound 1; then compound 3; then compounds 4 and 2 (each within the scatter of the next).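

Within the data shown here, at the amide-type nitrogen, the first measured change in this assay is a 1.4-fold lower number from compound 2 to compound 4 (0.15 log units; within the scatter), with tert-butyl in place of cyclohexyl. Compound 2 and compound 4 therefore cannot be told apart in this assay, so on this benzamide-bearing background, replacing a six-membered carbon ring with a group that has no ring leaves the number within the scatter. No measurement offered here accounts for this result.

The compounds shown do not reveal whether this substituent matters more when something other than an alkyl group stands on the nitrogen, such as a phenyl ring, a benzyl group, or a chain ending in an amine or a carboxylic acid. They also leave open whether the same exchange would stay within the scatter on the dimethylamino-substituted background of compound 3 or in the much lower range of compound 1, where the rest of the molecule differs from compound 2 in more than one place.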